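Adding a Chloro Group to a Triazole-Linked Sulfonamide

The source may report more compounds than this note shows. Statements on the series, on what has been measured and on what is new or still open speak of the compounds shown alone.

Measured compounds:
Compound 1: `O=c1[nH]cc(S(=O)(=O)Nc2ccccc2-c2cn(-c3ccc(Cl)cc3)nn2)c(=O)[nH]1` — 26700 nM
Compound 2: `O=c1[nH]cc(S(=O)(=O)Nc2ccc(-c3cn(-c4ccccc4)nn3)cc2)c(=O)[nH]1` — "not toxic" (no number reported)

Both compounds were tested in an ADME assay on GES1 cells (Homo sapiens) for cytotoxicity, read by MTT assay, with a stated time of 24 h; on this read-out higher numbers stand for lower toxicity in this test and lower numbers for higher toxicity in this test. Compound 1 gives 26700 nM in this assay. Compound 2 is reported in this assay as "not toxic" (no number reported), so no single number fixes where compound 2 stands; all that can be said is that compound 2 showed no measurable toxicity in this test.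

Compound 3, `O=c1[nH]cc(S(=O)(=O)Nc2ccc(-c3cn(-c4ccccc4Cl)nn3)cc2)c(=O)[nH]1`, differs from compound 2 by one change: chloro in place of hydrogen on an aromatic carbon. For the measured compounds named here, no step between two measured compounds shows how this change moves the read-out in this assay, so no size or direction beyond the usual scatter can be claimed from the data at hand. The closest point of comparison is compound 1, which gives 26700 nM in this assay and also carries a chlorine.

Compound 3 is expected to be weakly toxic at most, estimated at 35000 nM, with a range from 15000 nM to 100000 nM, and with a real chance that it is again reported without a number.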

Compound 3, half-maximal cytotoxic concentration: 16400 nM
The estimate for compound 3 lay 2.1-fold (0.33 log units) above the measured number; the range from low to high includes it.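

For the compounds shown here, compound 3 gives 16400 nM in this assay but compound 2 carries no number, so no step from compound 2 to compound 3 can be read. Going by these compounds, how far the 2-chlorophenyl group moves the read-out stays open. No measured evidence bears on this result.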